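A few compounds are considered here, and "the series" means these few. Any claim that something is new, unique, unknown or untested is made for them only; others in the source may bear on it.

Values so far in an ADME assay on cells (Hepatocyte, Mus musculus) for cytotoxicity, read by MTT assay, with a stated time of 24 h (a higher number here means that more compound is tolerated, a lower number that less compound is tolerated), for the series

- compound 1 `FC(F)(F)c1ccc(-c2nn(-c3ccccc3)cc2-c2nc3ccccc3[nH]2)cc1` gives 159000 nM
- compound 2 `Cc1ccc(-c2nn(-c3ccccc3)cc2-c2nc3ccccc3n2S(=O)(=O)c2ccc(F)cc2)cc1` gives 167000 nM
- compound 3 `COc1ccc(S(=O)(=O)n2c(-c3cn(-c4ccccc4)nc3-c3ccc(F)cc3)nc3ccccc32)cc1` gives 105000 nM

Compound 3 (105000 nM) stands within the usual scatter of both compound 1 (159000 nM) and compound 2 (167000 nM), so these numbers set no order among the three.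

The next compound to be tested is compound 4 `O=S(=O)(c1ccc(C(F)(F)F)cc1)n1c(-c2cn(-c3ccccc3)nc2-c2ccc(F)cc2)nc2ccccc21`, which carries trifluoromethyl in place of methoxy on an aromatic carbon of compound 3, para to a large group (trifluoromethyl in place of methoxy on an aromatic carbon). The same difference can be read as 4-methoxyphenyl to 4-(trifluoromethyl)phenyl.

Among the measured compounds shown here, no two measured compounds differ in one place only, so the series gives no direct reading of this change. With compound 3 (105000 nM) inside the scatter of the other two values, no step beyond the scatter is expected in this assay, in either direction. The expected step of a 1.1-fold higher number from compound 3 to compound 4 (0.06 log units; within the scatter) is therefore small. For compound 4 the estimated value is 120000 nM, with an expected range from 60000 nM to 220000 nM.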

Compound 4, half-maximal cytotoxic concentration: 55300 nM
Beside the measured number, compound 4's estimate is 2.2-fold (0.34 log units) above it, and the stated range ends above it.
By their numbers in this assay, from the lowest: compounds 4, 3, 1 and 2 (each within the scatter of the next, the first and the last beyond it).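

Among the compounds shown here, compound 3 and compound 4 form the first pair that differs in one place only, giving a direct reading of this exchange in this assay. Trifluoromethyl in place of methoxy on an aromatic carbon, para to a large group, gives a 1.9-fold lower number from compound 3 to compound 4 (0.28 log units; within the scatter), so this pair shows no change at this position that can be told from the scatter, even though a hydrogen-bond acceptor leaves and a larger group enters. Nothing available bears on the cause of this small step.

From the compounds shown here alone, whether an amine or a carboxylic acid at this position would move the number beyond the scatter remains open. Also open, going by these compounds, is whether the same exchange reads alike on a compound with a different group on the other aromatic ring of the shared core.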